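A Nitro Group on a Level Series

The compounds below may be only part of what the source reports. "The series", "measured", "known", "first", "only" and "open" are said of these compounds alone.

In a functional assay on HCT-116 cells (Homo sapiens) for cytotoxicity, with a stated time of 48 h (on this read-out lower numbers stand for stronger inhibition and higher numbers for weaker inhibition), compound 1 (`COc1cc(OC)c(C(=O)/C=C/c2ccccc2SC)c(OC)c1`) gives 6800 nM while compound 2 (`COc1cc(OC)c(C(=O)/C=C/c2ccccc2)c(OC)c1`) gives 6900 nM and compound 3 (`COc1cc(OC)c(C(=O)/C=C/c2ccc(Cl)cc2)c(OC)c1`) gives 5400 nM on the same scale. Compound 3 therefore stands level with the other two. Compound 4 (`COc1cc(OC)c(C(=O)/C=C/c2ccc([N+](=O)[O-])cc2)c(OC)c1`) differs from compound 3 by nitro in place of chloro on an aromatic carbon and so carries nitro in place of chloro on an aromatic carbon. Among the compounds with values here, two measured steps bear on this: chloro in place of hydrogen gave a 1.3-fold lower number from compound 2 to compound 3 (0.11 log units; within the scatter) and hydrogen in place of methylsulfanyl gave a 1.0-fold higher number from compound 1 to compound 2 (0.01 log units; within the scatter) with neither beyond the scatter. Within the data shown here, no nitro compound has been measured yet. In this assay the expected step is a 1.1-fold lower number from compound 3 to compound 4 (0.03 log units; within the scatter) and thus nothing beyond the scatter. Compound 4 is estimated at 5000 nM with an expected range from 2200 nM to 11000 nM in this assay.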

Compound 4, half-maximal inhibitory concentration: 2700 nM
Beside the measured number, compound 4's estimate is 1.9-fold (0.27 log units) above it; the range from low to high includes it.
By their numbers in this assay, from the lowest: compounds 4, 3, 1 and 2 (each within the scatter of the next, the first and the last beyond it).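

In this assay, within the data shown here, nitro para to a large group is the first change at this position to move the number beyond the scatter, though only modestly, with hydrogen as the reference (a 2.6-fold lower number from compound 2 to compound 4 (0.41 log units; beyond the scatter)). Against chloro at the same position, the step stays within the scatter (a 2.0-fold lower number from compound 3 to compound 4 (0.30 log units; within the scatter)), so nitro and chloro cannot be separated here. No available measurement speaks to what lies behind this step. Still open, from the compounds shown here alone, is whether an amine or a carboxylic acid at this position would give a number closer to that of nitro or that of hydrogen.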